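Aryl swap on the piperazine of an isatin thiosemicarbazone

A few compounds are considered here, and "the series" means these few. Any claim that something is new, unique, unknown or untested is made for them only; others in the source may bear on it.

Compound 1 `COc1ccc2c(c1)/C(=N/NC(=S)N1CCN(c3ccccc3)CC1)C(=O)N2` — 14400 nM
Compound 2 `O=C1Nc2cc(Cl)ccc2/C1=N/NC(=S)N1CCN(c2ccccc2)CC1` — 23000 nM
Compound 3 `Cc1ccc(N2CCN(C(=S)N/N=C3\C(=O)Nc4ccc(Cl)cc43)CC2)cc1` — 17100 nM

Three thiosemicarbazones built on a shared core have been tested in a functional assay on MCF7 cells (Homo sapiens) for inhibition, read by MTT assay, with a stated time of 72 h; a lower number here means a stronger inhibitor, a higher number a weaker inhibitor. In this assay compound 1 gives 14400 nM, compound 2 gives 23000 nM and compound 3 gives 17100 nM. The three numbers sit close together: the value of compound 3 differs from that of compound 1 and from that of compound 2 by gaps that fall within the usual scatter, so none of the three can be set apart from the others.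

Compound 4 `O=C1Nc2ccc(Cl)cc2/C1=N/NC(=S)N1CCN(c2ccccc2Cl)CC1` has not yet been measured. It differs from compound 3 in one place: 2-chlorophenyl in place of 4-methylphenyl on an amine nitrogen in a ring. Because compound 3 gives 17100 nM and the aryl groups already tried have left the numbers close together, no step beyond the scatter is expected from compound 3 to compound 4. Compound 4 is therefore estimated at 18000 nM, with a range from 7000 nM to 45000 nM; this estimate means a step of a 1.1-fold higher number from compound 3 to compound 4 (0.02 log units; within the scatter).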

Compound 4, half-maximal inhibitory concentration: 11700 nM
For compound 4 the middle estimate is 1.5-fold (0.19 log units) above the measured one; the measured number falls inside the stated range.
By their numbers in this assay, from the lowest: compounds 4, 1, 3 and 2 (each within the scatter of the next).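

On an amine nitrogen in a ring, putting 2-chlorophenyl in place of 4-methylphenyl gives a 1.5-fold lower number from compound 3 to compound 4 (0.16 log units; within the scatter) in this assay. This is the first pair among the compounds shown that differs in one place, and it shows that this exchange, which keeps the heavy-atom count and adds chlorine, produces no step beyond the scatter at this position. Nothing measured here accounts for the size of this step.

The compounds shown leave open whether a group of another kind on this nitrogen, such as a benzyl group, an acetyl group or a chain carrying a carboxylic acid, would produce a step beyond the scatter. They also leave open whether the same exchange would give a similar step on the core of compound 1.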